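The compounds below may be only part of what the source reports. "The series", "measured", "known", "first", "only" and "open" are said of these compounds alone.

Working notes on the series. Compound 1 `Cc1cn(C2CCN(Cc3cccc(OC4CCCCC4)c3)CC2)c(=O)[nH]c1=O` in an ADME assay on MRC5 cells (Homo sapiens) for cytotoxicity, read by fluorescence and resazurin assay, with a stated time of 3 days (on this read-out lower numbers stand for stronger inhibition and higher numbers for weaker inhibition), gives 23600 nM. Compound 2 `Cc1cn(C2CCN(Cc3cccc(Oc4ccncc4)c3)CC2)c(=O)[nH]c1=O` has no result in this assay, recorded as "not determined" (no result reported). Compound 3 `Cc1cn(C2CCN(Cc3cccc(Oc4cccc(F)c4)c3)CC2)c(=O)[nH]c1=O` reaches only a limit of this assay, > 64000 nM, and no single number is known for it because of the limit of > 64000 nM in this assay, at which 1 of the 3 values shown sits. Among the measured compounds shown here, the one measured step, an at least 2.7-fold higher number from compound 1 to compound 3 (0.43 log units; beyond the scatter), runs toward that limit. Compound 4 `Cc1cn(C2CCN(Cc3cccc(Oc4ccccn4)c3)CC2)c(=O)[nH]c1=O` differs from compound 3 by pyridin-2-yl in place of 3-fluorophenyl on an oxygen on an aromatic ring. For the measured compounds named here, no measured step covers this pair directly; the only step at this position, 3-fluorophenyl in place of cyclohexyl, was at least modest and ended at the limit. Compound 4 is therefore expected to show no step beyond the scatter, a step that the limit leaves unreadable from compound 3 to compound 4, most probably again a limit. Compound 4 is estimated at 70000 nM, within 30000 nM to 200000 nM.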

Compound 4, half-maximal inhibitory concentration: > 64000 nM
Compound 4 was reported as a limit (the forecaster's own chance of this, stated with the estimate: 65%); the middle value does not contradict the limit.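

In this assay, pyridin-2-yl in place of cyclohexyl gives an at least 2.7-fold higher number from compound 1 to compound 4 (0.43 log units; beyond the scatter), so the higher number at this position is not tied to 3-fluorophenyl alone. Compound 4 sits at a limit of the assay, > 64000 nM, and is not a number. The step between 3-fluorophenyl and pyridin-2-yl cannot be read: the limit of > 64000 nM in this assay, at which 2 of the 4 values shown sit.

From the compounds shown here alone, how far compound 3 and compound 4 lie past the limit stays open. Also open, going by these compounds, is whether a longer alkyl chain or an amine on the oxygen would give a readable number.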